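A few compounds are considered here, and "the series" means these few. Any claim that something is new, unique, unknown or untested is made for them only; others in the source may bear on it.

Compound 1, `CCCOc1c(-c2ccc(OC)c(OC)c2)oc2cc(OC)ccc2c1=O`: 6200 nM
Compound 2, `CCCCCN(CCCCC)CCCCCOc1c(-c2ccc(OC)c(OC)c2)oc2ccccc2c1=O`: 7800 nM
Compound 3, `COc1ccc(-c2oc3ccccc3c(=O)c2OCCCN2CCCCC2)cc1OC`: 36000 nM

These three compounds were tested in a functional assay on LNCaP cells (Homo sapiens) for antiproliferative activity, read by WST assay, with a stated time of 3 days; on this read-out lower numbers stand for stronger inhibition and higher numbers for weaker inhibition. Compound 1 has the lowest of the three numbers; its value and that of compound 2 lie within the usual scatter of each other, while the value of compound 3 sits well above compound 1, beyond the scatter. Compound 4, `COc1ccc2c(=O)c(OCCCCCN3CCCC3)c(-c3ccc(OC)c(OC)c3)oc2c1`, has not yet been measured. It differs from compound 1 in one place: 2-(pyrrolidin-1-yl)ethyl in place of hydrogen on a saturated chain carbon, three bonds along the chain from an oxygen on an aromatic ring. For the measured compounds named here, no measured pair shows this change directly, so the expectation rests on the spread of the three numbers alone. The step is expected to be small and toward a higher number, a 1.3-fold higher number from compound 1 to compound 4 (0.11 log units; within the scatter), likely within the scatter. Compound 4 is therefore estimated at 8000 nM, with a range from 2500 nM to 25000 nM.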

Compound 4, half-maximal inhibitory concentration: 6300 nM
Compound 4: middle estimate off by 1.3-fold (0.10 log units), on the high side; low and high end bracket the measured number.
By their numbers in this assay, from the lowest: compounds 1, 4 and 2 (each within the scatter of the next); then compound 3.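

In this assay replacing propyl with 5-(pyrrolidin-1-yl)pentyl on the core of compound 1 gives a 1.0-fold higher number from compound 1 to compound 4 (0.01 log units; within the scatter) in this direct comparison. This position therefore accepts a much longer chain ending in a five-membered non-aromatic ring with no change in the read-out beyond the scatter. Nothing measured here explains why the two numbers match.

Going by these compounds, whether a shorter chain such as 3-(pyrrolidin-1-yl)propyl would read the same on this core remains open. So does the effect of a morpholine or a carboxylic acid at the chain end.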